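Replacing the carbamate cap on the ring nitrogen

This account rests on a few compounds, and the source may have more. Where it says the series, first, only, none or still open, it means among the compounds named here.

Measured compounds:
compound 1 `CC(C)S(=O)(=O)c1cnc(O[C@H]2CC[C@H](OC3CCN(C(=O)OC(C)(C)C)CC3)CC2)cn1`: 128%
compound 2 `CC(C)(C)OC(=O)N1CCC(O[C@H]2CC[C@H](Oc3ccc(S(C)(=O)=O)nn3)CC2)CC1`: 86%
compound 3 `CC1(OC(=O)N2CCC(O[C@H]3CC[C@H](Oc4cnc(S(C)(=O)=O)cn4)CC3)CC2)CC1`: 123%

In a functional assay on isolated protein for agonist activity at Glucose-dependent insulinotropic receptor (Rattus norvegicus), read by HTRF and cAMP accumulation (a lower number here means a smaller maximal response, a higher number a larger maximal response), compound 3 gives 123%, the second highest of the three numbers. Compound 1 is the nearest, and the gap to it lies within the usual scatter; compound 2 is the furthest, and that gap lies beyond the scatter.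

Compound 4 `CS(=O)(=O)c1cnc(O[C@H]2CC[C@H](OC3CCN(CC4(C(F)(F)F)CC4)CC3)CC2)cn1` differs from compound 3 in one place: (1-(trifluoromethyl)cyclopropyl)methyl in place of ((1-methylcyclopropyl)oxy)carbonyl on an amine nitrogen in a ring. For the measured compounds named here, no measured pair shows this change, so there is nothing to build on directly. A modest downward step is expected, possibly still within the scatter, which is what the estimated step of a number 13 percentage points lower from compound 3 to compound 4 (beyond the scatter) means. In this assay compound 4 is therefore estimated at 110%, with a likely range from 80% to 135%.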

Compound 4, largest response reached (Emax), in percent of the reference or control that the assay uses: 124%
Compound 4: the middle estimate sits 14 percentage points below what was measured; measured number inside the range.
By their numbers in this assay, from the lowest: compound 2; then compounds 3, 4 and 1 (each within the scatter of the next).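

Putting (1-(trifluoromethyl)cyclopropyl)methyl in place of ((1-methylcyclopropyl)oxy)carbonyl on an amine nitrogen in a ring gives a number 1 percentage points higher from compound 3 to compound 4 (within the scatter) in this assay. For this pair, then, a large response does not require the carbonyl or the two hydrogen-bond acceptors of the group that leaves. No supporting measurement accounts for this result. Going by these compounds, it remains open whether a longer alkyl chain or a sulfonamide on this nitrogen would give a similar response. Also open, on these data alone, is whether this replacement would give a similar result on the cores of compound 1 and compound 2.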